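The compounds below may be only part of what the source reports. "The series", "measured", "known", "first", "only" and "open" are said of these compounds alone.

Measured so far:
- compound 1, `C=C1CC(COc2cccc3ccc(C)nc23)(c2ccccc2)OC1=O`: 2090 nM
- compound 2, `C=C1CC(COc2cccc3ccccc23)(c2ccccc2)OC1=O`: 10500 nM

In a functional assay on TK-10 cells (Homo sapiens) for antiproliferative activity (on this read-out higher numbers stand for weaker inhibition of growth and lower numbers for stronger inhibition of growth), compound 1 gives 2090 nM, the lower of the two numbers in hand. Compound 2 gives 10500 nM in this assay, and the gap between the two lies beyond the usual scatter. Among the compounds with values here, the two compounds differ in more than one place, so the numbers alone do not tell which part of the difference carries the gap, and no single-change step between measured compounds is available.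

Compound 3, `C=C1CC(COc2cccc3cccnc23)(c2ccccc2)OC1=O`, has not yet been measured in this assay. It differs from compound 1 in one place only: hydrogen in place of methyl on an aromatic carbon. Within the data shown here, no measured pair isolates this change, so the expectation rests on compound 1 alone, with compound 2 marking how far the numbers have been seen to move. The step of a 1.7-fold higher number from compound 1 to compound 3 (0.22 log units; within the scatter) is expected to be small, toward weaker inhibition of growth, and is judged likely to fall within or only just beyond the scatter. Compound 3 is therefore estimated at 3500 nM, with a range from 1200 nM to 10000 nM.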

Compound 3, concentration for 50% growth inhibition: 1660 nM
Estimate against measurement, compound 3: 2.1-fold (0.32 log units) above; measured number inside the range.
By their numbers in this assay, from the lowest: compounds 3 and 1 (each within the scatter of the next); then compound 2.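

In this assay, replacing methyl with hydrogen on this aromatic carbon next to the ring nitrogen gives a 1.3-fold lower number from compound 1 to compound 3 (0.10 log units; within the scatter), so the methyl can be lost here with no readable change in the number. Within the data shown here, this is the first single-change step, and it shows that the methyl is not needed to keep the number in the range of compound 1. With the methyl gone, compound 3 gives 1660 nM and compound 2 gives 10500 nM, so the methyl does not carry the gap seen earlier, although no measurement at hand explains why either number takes the value it does.

This single step leaves open whether the position accepts only hydrogen and methyl or also larger or different groups, such as an ethyl, a methoxy, an amine or a carboxylic acid. The compounds shown also leave open whether the same replacement would give so small a step with the phenyl or the methylidene lactone part of the core altered.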